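Replacing a Sulfur Link by a Benzylamine on a Shared Core

This account rests on a few compounds, and the source may have more. Where it says the series, first, only, none or still open, it means among the compounds named here.

Of the compounds shown here, three built on one shared core have been tested in a functional assay on DU-145 cells (Homo sapiens) for inhibition, read by sulforhodamine B assay, with a stated time of 48 h; on this read-out higher numbers stand for lower toxicity in this test and lower numbers for higher toxicity in this test. Compound 1 `Nc1cc(N)c2nc(-c3ccccc3)c(Sc3ccc(F)cc3)nc2c1` gives in this assay < 100000 nM, which is a limit of the assay rather than a number. Compound 2 `COc1cc(CNc2nc3cc(N)cc(N)c3nc2-c2ccccc2)cc(OC)c1OC` likewise gives only a limit, < 50200 nM. Compound 3 `CCOC(=O)[C@H](CCC(=O)O)NC(=O)c1ccc(CNc2nc3cc(N)cc(N)c3nc2-c2ccccc2)cc1` also stops at a limit, < 100000 nM. Compound 1 therefore stands nowhere definite among the numbers shown: all three results are limits, two at the limit of < 100000 nM in this assay, at which 2 of the 3 values shown sit, and one at the limit of < 50200 nM in this assay, at which 1 of the 3 values shown sits, so no measured step between these compounds can be read and no order among them can be set.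

Compound 4 `Nc1cc(N)c2nc(-c3ccccc3)c(NCc3ccc(F)cc3)nc2c1` has not yet been measured. It differs from compound 1 in one place: (4-fluorobenzyl)amino in place of (4-fluorophenyl)sulfanyl on an aromatic carbon. Among the compounds with values here, only limits are known for compound 1, and no direction of the step can be drawn from them; the expected step is a step that the limit leaves unreadable from compound 1 to compound 4, not expected to reach beyond the scatter. Compound 4 is expected to show about 60000 nM, between 15000 nM and 150000 nM, most likely again as a limit of the assay.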

Compound 4, concentration lethal to 50% of the cells: 9770 nM
The estimate for compound 4 lay 6.1-fold (0.79 log units) above the measured number, outside the stated range (below it).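

Compound 4 gives a plain number, but compound 1 has only a limit of the assay, so no step from compound 1 to compound 4 can be read: the limit of < 100000 nM in this assay, at which 2 of the 4 values shown sit.

The compounds shown leave open whether (4-fluorobenzyl)amino in place of (4-fluorophenyl)sulfanyl changes the result in this assay at all, and in which direction.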